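Capping the aromatic amine of compound 3 with acetyl

The source may hold more compounds than are shown below. What is called first, only, known or untested is meant among the compounds shown, and "the series" means these compounds.

Of the compounds shown here, three sharing one core have been measured in an assay on HEK293 cells for displacement of a labelled ligand from 5-hydroxytryptamine receptor 6 (Homo sapiens), with a stated time of 60 min, tested at 1 uM, in the presence of a further agent that is not named here; on this read-out lower numbers stand for a weaker effect and higher numbers for a stronger effect at the one concentration tested. Compound 1 `COc1ccc(S(=O)(=O)NCCN2CCC(CCC(=O)c3cc(Cl)c(N)cc3OC)CC2)cc1Br` gives 72%, compound 2 `COc1cc(N)c(Cl)cc1C(=O)CCC1CCN(CCNS(=O)(=O)c2ccc(C)cc2)CC1` gives 15%, and compound 3 `COc1cc(N)c(Cl)cc1C(=O)CCC1CCN(CCNS(=O)(=O)c2ccc(N)cc2)CC1` gives 46%. Compound 3 therefore stands second of the three: it is below compound 1, the step being a number 26 percentage points lower from compound 1 to compound 3 (beyond the scatter), and above compound 2, the step being a number 31 percentage points higher from compound 2 to compound 3 (beyond the scatter).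

Compound 4 `COc1cc(N)c(Cl)cc1C(=O)CCC1CCN(CCNS(=O)(=O)c2ccc(NC(C)=O)cc2)CC1` has not been measured. It differs from compound 3 in one place: acetyl in place of hydrogen on a nitrogen on an aromatic ring.

Among the compounds with values here, no measured step changes that nitrogen itself, so the bearing of the measured steps is indirect. The step of a number 31 percentage points higher from compound 2 to compound 3 (beyond the scatter) shows that the group on that aromatic carbon moves the read-out a long way, and the step of a number 57 percentage points lower from compound 1 to compound 2 (beyond the scatter) shows the same region is sensitive overall. Because a number 31 percentage points higher from compound 2 to compound 3 (beyond the scatter) is large, a change at the same position is expected to matter beyond the scatter, and with the amine now carrying an acetyl, a modest to large drop is expected rather than a gain. The step in this assay from compound 3 to compound 4 is estimated at a number 13 percentage points lower from compound 3 to compound 4 (beyond the scatter). Compound 4 is expected to give about 33%, plausibly anywhere between 10% and 60%.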

Compound 4, a percentage reported as inhibition, at one concentration (the size of the read-out at that concentration, not a potency): 67%
Compound 4: middle estimate off by 34 percentage points, on the low side; the whole stated range lies below it.
By their numbers in this assay, from the lowest: compound 2; then compound 3; then compounds 4 and 1 (each within the scatter of the next).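

Capping the nitrogen does not cost activity at this position: in this assay, adding the acetyl gives a number 21 percentage points higher from compound 3 to compound 4 (beyond the scatter), so a bare amino group is not needed for this read-out and the position accepts a larger group. The comparison with the methyl group widens to a number 52 percentage points higher from compound 2 to compound 4 (beyond the scatter), which shows that the gain seen with amino over methyl continues with acetamido, and that this position can carry the read-out much further than the amino compound alone suggested. The 4-acetamidophenyl group also brings the series level with the 3-bromo-4-methoxyphenyl group, with a number 5 percentage points lower from compound 1 to compound 4 (within the scatter), so a single group on this ring can match that two-group pattern, although nothing available here explains why the acetyl raises the number.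

The compounds shown leave open whether the gain belongs to acetyl specifically or would also appear with a longer acyl chain such as propanoyl, or with a methanesulfonyl group on the same nitrogen. Each number also comes from a single concentration, so the effect of compound 4 and compound 1 is known at that concentration only.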